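The source may report more compounds than this note shows. Statements on the series, on what has been measured and on what is new or still open speak of the compounds shown alone.

Among the compounds with values here, compound 1 `O=C(C1CCC(F)(F)CC1)N1CC(c2nc(-c3cccc(Cl)c3)no2)C1` is the only compound with an actual number: in an assay on HEK293 cells for positive allosteric modulation of metabotropic glutamate receptor 5 (Homo sapiens), read by FLIPR (on this read-out lower numbers stand for an effect already at smaller amounts and higher numbers for an effect only at larger amounts of compound), compound 1 gives 180 nM. Compound 2 `O=C(c1ccccc1F)N1CC[C@H]1c1nc(-c2cccc(F)c2)no1` gives > 10000 nM, which is a limit of the assay rather than a number, namely (the limit of > 10000 nM in this assay, at which 1 of the 2 values shown sits). Compound 3 `O=C([C@H]1CC2CCC1C2)N1CC(c2nc(-c3cccc(Cl)c3)no2)C1` has not yet been measured. Compared with compound 1 it carries a group of 7 heavy atoms (7 carbon; 2 five-membered non-aromatic rings of carbon only) in place of a group of 8 heavy atoms (6 carbon, 2 fluorine; one six-membered non-aromatic ring of carbon only), on a carbonyl carbon. Within the data shown here, no measured pair of compounds differs in this one place, so the size of the step is open. Compound 3 is expected to give about 250 nM, between 80 nM and 800 nM. The step of a 1.4-fold higher number from compound 1 to compound 3 (0.14 log units; within the scatter) is expected to stay within the usual scatter.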

Compound 3, half-maximal effective concentration: 74 nM
The estimate for compound 3 lay 3.4-fold (0.53 log units) above the measured number, outside the stated range (below it).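

Replacing the 4,4-difluorocyclohexyl on the carbonyl carbon with the all-carbon group of two five-membered rings gives, in this assay, a 2.4-fold lower number from compound 1 to compound 3 (0.39 log units; beyond the scatter). Within the data shown here, this is the first measured change at this place: it shows that the effect depends on the group there, and that the two fluorines of compound 1 can go while the effect appears at smaller amounts. Nothing shown here explains this step.

On these data alone, whether an open chain such as a pentyl group, or a ring carrying an amine or a carboxylic acid, would fare as well at this place remains open. So does the contribution of the defined stereocentre in compound 3.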